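A few compounds are considered here, and "the series" means these few. Any claim that something is new, unique, unknown or untested is made for them only; others in the source may bear on it.

In a functional assay on HeLa cells (Homo sapiens) for antiproliferative activity, read by MTT assay (a higher number here means a weaker inhibitor, a lower number a stronger inhibitor), compound 1 `Clc1ccc(Nc2nccc(-c3ccc(Br)cc3)n2)c(Cl)c1` gives 1080 nM while compound 2 `COc1cccc(Nc2nccc(-c3ccc(F)cc3)n2)c1` gives 145000 nM and so holds the higher, weaker of the two numbers, beyond the scatter. Compound 3 `COc1ccc(-c2ccnc(Nc3cccc(OC)c3)n2)cc1` differs from compound 2 at one place (methoxy in place of fluoro on an aromatic carbon) with methoxy in place of fluoro on an aromatic carbon, para to a large group. Among the compounds with values here, no measured step covers this change, so only a small move toward a lower number is expected, perhaps none beyond the scatter: the estimated step is a 2.1-fold lower number from compound 2 to compound 3 (0.32 log units; beyond the scatter) and no more. In this assay the estimated value for compound 3 is 70000 nM (expected range 15000 nM to 250000 nM).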

Compound 3, half-maximal inhibitory concentration: 550 nM
The estimate for compound 3 lay 130-fold (2.10 log units) above the measured number; the whole stated range lies above it.
By their numbers in this assay, from the lowest: compounds 3 and 1 (each within the scatter of the next); then compound 2.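

In this assay, methoxy in place of fluoro on an aromatic carbon, para to a large group, gives a 260-fold lower number from compound 2 to compound 3 (2.42 log units; beyond the scatter) as a large step from this single change. This position therefore has a strong bearing on the read-out with the rest of compound 2 held fixed, which the earlier pair, differing in more than one place, could not isolate. Nothing at hand explains the size of this step.

Open, on these data alone, is whether the oxygen or the attached methyl carries the step; hydroxyl, ethoxy or dimethylamino at this position would help separate the two. Also open, as far as these compounds go, is whether the same change holds on the core of compound 1.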